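Replacing Cyclohexylamino with Azetidinyl on a Weak Compound

The compounds below may be only part of what the source reports. "The series", "measured", "known", "first", "only" and "open" are said of these compounds alone.

Compound 1 `O=C1C=C(Nc2ccc(I)cc2)C(=O)c2c1nc1n2[C@H]2OC[C@@H](O)[C@H]2OC1` sets the reference: in a functional assay on MGC-803 cells (Homo sapiens) for inhibition, read by sulforhodamine B assay (on this read-out lower numbers stand for stronger inhibition and higher numbers for weaker inhibition), compound 1 gives 1400 nM. Compound 3 `CCOc1ccccc1NC1=CC(=O)c2nc3n(c2C1=O)[C@H]1OC[C@@H](O)[C@H]1OC3`, with 2-ethoxyphenyl on the amine nitrogen instead, gives 2450 nM, a change recorded as a 1.8-fold higher number from compound 1 to compound 3 (0.24 log units; within the scatter). Compound 2 `O=C1C=C(NC2CCCCC2)C(=O)c2c1nc1n2[C@H]2OC[C@@H](O)[C@H]2OC1` carries cyclohexylamino on the shared core. For compound 2 only a limit is reported, > 8000 nM. The step of an at least 5.7-fold higher number from compound 1 to compound 2 (0.75 log units; beyond the scatter) and the step of an at least 3.2-fold lower number from compound 2 to compound 3 (0.51 log units; beyond the scatter) both place compound 2 at the weak end of the three. Compound 4 `O=C1C=C(N2CCC2)C(=O)c2c1nc1n2[C@H]2OC[C@@H](O)[C@H]2OC1` is not yet measured; it differs from compound 2 as azetidin-1-yl in place of cyclohexylamino on a double-bonded ring carbon. Both measured steps concern a swap of the ring on the amine nitrogen and point the same way: a non-aromatic ring in that position reads weaker than an aromatic one, and nothing among them suggests that a smaller non-aromatic ring, now without the amine hydrogen, would recover inhibition. Compound 4 is therefore expected to sit again at the limit of > 8000 nM in this assay, at which 1 of the 3 values shown sits, estimated at 9000 nM within 2500 nM to 30000 nM. The expected step that the limit leaves unreadable from compound 2 to compound 4 is thus none beyond the scatter.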

Compound 4, half-maximal inhibitory concentration: > 16000 nM
Compound 4: only a limit was reported (the forecaster's own chance of this, stated with the estimate: 60%); at least 1.7-fold (0.24 log units) between middle value and limit.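

Compound 4 again reaches only a limit, now the highest shown in this assay: the limit of > 16000 nM in this assay, at which 1 of the 4 values shown sits. Within the data shown here, with azetidin-1-yl at this place, the record shows an at least 11-fold higher number from compound 1 to compound 4 (1.05 log units; beyond the scatter) and extends the weak readings to a non-aromatic ring attached through its own nitrogen, with no amine hydrogen left, whereas the earlier compounds all kept that hydrogen. The step between compound 2 and compound 4 cannot be read, so the two cannot be ranked and the data do not separate the smaller ring from the larger one.

The compounds shown leave open whether the loss of the amine hydrogen or the non-aromatic ring itself goes with the weak readings. Cyclobutylamino, which keeps the amine hydrogen on a small carbon ring, and N-methylanilino, which removes it from an aromatic substituent, would address that question.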